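Hydroxycyclohexyl replaces carbamoylcyclohexyl on the aminopyridine nitrogen

A few compounds are considered here, and "the series" means these few. Any claim that something is new, unique, unknown or untested is made for them only; others in the source may bear on it.

Measured compounds:
Compound 1 `N#Cc1cnc(NCc2cnccc2C(F)(F)F)cc1NC[C@H]1CC[C@@H](O)CC1` gives 500 nM in an assay on isolated protein for inhibition of protein kinase C delta type (Homo sapiens), read by TR-FRET, with a stated time of 2 h; a higher number here means a weaker inhibitor, a lower number a stronger inhibitor.
Compound 2 `CO[C@H]1CC[C@H](CNc2cc(NCc3cnccc3C(F)(F)F)ncc2C#N)CC1` gives > 10000 nM in this assay, which is a limit of the assay and not a number.
Compound 3 `N#Cc1cnc(NCc2cnccc2C(F)(F)F)cc1N[C@H]1CC[C@@H](C(N)=O)CC1` gives 400 nM in this assay.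

Compound 3 has the lowest number of the two numbers shown, with compound 1 nearest a 1.3-fold lower number from compound 1 to compound 3 (0.10 log units; within the scatter). Compound 4 `CC1(C)C[C@H](Nc2cc(NCc3cnccc3C(F)(F)F)ncc2C#N)CC[C@H]1O` differs from compound 3 by 4-hydroxy-3,3-dimethylcyclohexyl in place of 4-carbamoylcyclohexyl on a nitrogen on an aromatic ring. Among the compounds with values here, two steps bear on this change. The 4-hydroxycyclohexyl group of compound 1 lies close to the 4-carbamoylcyclohexyl of compound 3 in the step of a 1.3-fold lower number from compound 1 to compound 3 (0.10 log units; within the scatter), while capping that hydroxyl as methoxy gave an at least 20-fold higher number from compound 1 to compound 2 (1.30 log units; beyond the scatter), at the limit (the limit of > 10000 nM in this assay, at which 1 of the 3 values shown sits). A free hydroxyl on the cyclohexyl is therefore expected to keep compound 4 near compound 3, with the two added methyl groups untested. The estimated step is a 1.5-fold higher number from compound 3 to compound 4 (0.18 log units; within the scatter), within the scatter. Compound 4 is estimated at 600 nM, ranging from 150 nM to 3000 nM.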

Compound 4, half-maximal inhibitory concentration: 2200 nM
Compound 4: the middle estimate sits 3.7-fold (0.56 log units) below what was measured; measured number inside the range.
By their numbers in this assay, from the lowest: compounds 3 and 1 (each within the scatter of the next); then compound 4. At a limit, above all of these: compound 2.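

Within the data shown here, compound 4 shows that a free hydroxyl on the cyclohexyl does not by itself hold the level of the earlier compounds at this nitrogen, with a 5.5-fold higher number from compound 3 to compound 4 (0.74 log units; beyond the scatter) and a 4.4-fold higher number from compound 1 to compound 4 (0.64 log units; beyond the scatter). The hydroxyl-bearing ring with its two methyl groups still reads clear of the methoxy compound, with an at least 4.5-fold lower number from compound 2 to compound 4 (0.65 log units; beyond the scatter). That last step is a bound, as compound 2 gives a limit and not a number: the limit of > 10000 nM in this assay, at which 1 of the 4 values shown sits.

Still open, as far as these compounds go, is how the plain 4-hydroxycyclohexyl on this nitrogen would compare, which would separate the two methyl groups from the hydroxyl. Also open, from the compounds shown here alone, is how an amine or a carboxylic acid at that ring position would read.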